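Furan to Thiophene on a Shared Core: An Expectation

This account rests on a few compounds, and the source may have more. Where it says the series, first, only, none or still open, it means among the compounds named here.

Compound 1, `CCCOC(=O)C1=C(C)NC(=O)NC1c1ccoc1`: 50%
Compound 2, `CC1=C(C(=O)OC(C)(C)C)C(c2ccoc2)NC(=O)N1`: 11%
Compound 3, `CC1=C(C(=O)CC(C)C)C(c2ccoc2)NC(=O)N1`: 23%

All three values come from an assay on membranes from CHO cells for displacement of a labelled ligand from adenosine receptor A1 (Homo sapiens), read by scintillation counting, with a stated time of 60 min, tested at 1 uM; on this read-out lower numbers stand for less inhibition and higher numbers for more inhibition at the one concentration tested (going by the name of the read-out). Among the three measured compounds, compound 3 stands second highest. Its nearest neighbour is reached by a number 12 percentage points higher from compound 2 to compound 3 (beyond the scatter), and its furthest by a number 27 percentage points lower from compound 1 to compound 3 (beyond the scatter). The third measured step, a number 39 percentage points lower from compound 1 to compound 2 (beyond the scatter), is the largest of all. Every one of these steps changes the group on the carbonyl carbon; none of them touches the aromatic ring on the saturated ring carbon.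

Compound 4, `CC1=C(C(=O)CC(C)C)C(c2cccs2)NC(=O)N1`, differs from compound 3 in exactly that untested place: thiophen-2-yl in place of furan-3-yl on a saturated ring carbon. Among the compounds with values here, no measured step bears on this change, so the data give no direction for it. The expectation is therefore a step that stays within the usual scatter, a number 2 percentage points higher from compound 3 to compound 4 (within the scatter). On that basis compound 4 is estimated at 25%, with a range from 5% to 50% in this assay.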

Compound 4, a percentage reported as inhibition, at one concentration (the size of the read-out at that concentration, not a potency): 19%
Compound 4: the middle estimate sits 6 percentage points above what was measured; the range from low to high includes it.
By their numbers in this assay, from the lowest: compounds 2, 4 and 3 (each within the scatter of the next, the first and the last beyond it); then compound 1.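

In this assay, within the data shown here, the aromatic ring on the saturated ring carbon is varied for the first time, and thiophen-2-yl in place of furan-3-yl gives a number 4 percentage points lower from compound 3 to compound 4 (within the scatter), so with the isobutylcarbonyl group held constant the two rings cannot be told apart. The earlier steps shown here all changed the group on the carbonyl carbon and all went beyond the scatter, whereas this ring change does not, although it alters both the hetero atom, sulfur for oxygen, and the point of attachment, and the two alterations cannot be separated here. No available evidence bears on this result.

From the compounds shown here alone, whether furan-2-yl, thiophen-3-yl, phenyl or pyridyl would read the same at this place remains open. So does whether thiophen-2-yl would match furan-3-yl alongside the propyl ester of compound 1.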